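Adding a Methoxy Group on the Second Aromatic Ring

The source may report more compounds than this note shows. Statements on the series, on what has been measured and on what is new or still open speak of the compounds shown alone.

Compound 1, `CCCOC(=O)N1N=C(c2ccccc2)CC1c1cc(OC)c(OC)c(OC)c1`, in a functional assay on A2780 cells (Homo sapiens) for antiproliferative activity, read by MTT assay, with a stated time of 48 h (on this read-out lower numbers stand for stronger inhibition of growth and higher numbers for weaker inhibition of growth), compound 1 gives 10800 nM.
Compound 2, `CCCOC(=O)N1N=C(c2ccc(OC)cc2)CC1c1cc(OC)c(OC)c(OC)c1`, in this assay compound 2 gives 11700 nM.
Compound 3, `COC(=O)N1N=C(c2ccccc2)CC1c1ccc(OC)c(OC)c1`, in this assay compound 3 gives 29900 nM.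

Compound 2 differs from compound 1 by one change, (methoxy in place of hydrogen on an aromatic carbon), and the step it made was a 1.1-fold higher number from compound 1 to compound 2 (0.03 log units; within the scatter). The difference between the core of compound 3 and the core of compound 1 is not broken down here; compound 3 simply shows the highest of the three numbers.

Compound 4, `COC(=O)N1N=C(c2ccccc2)CC1c1cc(OC)c(OC)cc1OC`, differs from compound 3 by methoxy in place of hydrogen on an aromatic carbon. This is the same kind of change as that from compound 1 to compound 2, but not the same: there the new group sat para to a large group, here it sits ortho to a large group, meta to a methoxy group and para to a methoxy group. Because a 1.1-fold higher number from compound 1 to compound 2 (0.03 log units; within the scatter) stayed within the scatter, the step from compound 3 to compound 4 is expected to be small, a 1.0-fold higher number from compound 3 to compound 4 (0.00 log units; within the scatter). Compound 4 is therefore estimated at 30000 nM, expected between 12000 nM and 75000 nM.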

Compound 4, concentration for 50% growth inhibition: > 10000 nM
Compound 4 ended at the assay's limit (the forecaster's own chance of this, stated with the estimate: 10%); the middle value does not contradict the limit.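

Compound 4 gives > 10000 nM, which is a limit of the assay and not a number. The step from compound 3 to compound 4 therefore cannot be read. As far as these compounds go, whether this added methoxy group changes growth inhibition in this assay stays open.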